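From compound 2 to compound 3: fluoro to chloro

The source may hold more compounds than are shown below. What is called first, only, known or untested is meant among the compounds shown, and "the series" means these compounds.

In an ADME assay on MCF7 cells (Homo sapiens) for cytotoxicity, read by MTT assay, with a stated time of 48 h (a lower number here means a stronger inhibitor, a higher number a weaker inhibitor), compound 2 (`Fc1ccc(-c2[nH]c3cc(F)ccc3c2Cn2cncn2)cc1`) gives only a limit, > 1000000 nM, and no number. Compound 1 (`Fc1ccc2c(Cn3ccnc3)c(-c3ccc(Cl)cc3)[nH]c2c1`) gives a measured 45000 nM in this assay. Compound 3 (`Fc1ccc2c(Cn3cncn3)c(-c3ccc(Cl)cc3)[nH]c2c1`) has chloro in place of fluoro on an aromatic carbon, para to a large group, 4-fluorophenyl to 4-chlorophenyl (chloro in place of fluoro on an aromatic carbon). Among the measured compounds shown here, no measured pair isolates this change. A step toward stronger inhibition is expected in this assay, estimated as an at least 8.3-fold lower number from compound 2 to compound 3 (0.92 log units; beyond the scatter). The expectation rests on compound 1, which carries 4-chlorophenyl and gives 45000 nM. The estimate for compound 3 is 120000 nM, with an expected range of 40000 nM to 600000 nM.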

Compound 3, half-maximal inhibitory concentration: > 1000000 nM
Compound 3: no number, only a limit (the forecaster's own chance of this, stated with the estimate: 25%); middle value at least 8.3-fold (0.92 log units) away from the limit.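

Among the compounds shown here, with 4-chlorophenyl held fixed, 1H-1,2,4-triazol-1-yl in place of 1H-imidazol-1-yl on the saturated chain carbon gives the only readable step in this assay: an at least 22-fold higher number from compound 1 to compound 3 (1.34 log units; beyond the scatter). Compound 3 gives only a limit, > 1000000 nM. The step from 4-fluorophenyl to 4-chlorophenyl cannot be read, because compound 2 and compound 3 both stand at that limit: the limit of > 1000000 nM in this assay, at which 2 of the 3 values shown sit.

As far as these compounds go, the full size of the step from 1H-imidazol-1-yl to 1H-1,2,4-triazol-1-yl stays open, as does the effect of fluoro against chloro with 1H-imidazol-1-yl in place. From the compounds shown here alone, how an amine or a carboxylic acid on that chain carbon would read in this assay also stays open.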